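The source may report more compounds than this note shows. Statements on the series, on what has been measured and on what is new or still open speak of the compounds shown alone.

Measured compounds:
compound 1 `COc1cc2c(cc1O)CCC(C)(CC(N)=O)O2`: 100%
compound 2 `COc1cc2c(cc1O)CCC(C)(CCNC(=O)C[C@H]1OC(O)[C@H](O)[C@@H](O)[C@@H]1O)O2`: 87.2%

In an ADME assay on SH-SY5Y cells (Homo sapiens) for cytotoxicity, read by MTT assay, with a stated time of 24 h, tested at 6.3 uM (a higher number here means a weaker effect of the compound at the concentration tested, a lower number a stronger effect), compound 1 gives 100%, a number that shows no measurable effect at the concentration tested. Compound 2 gives 87.2% in this assay, the lowest of the two numbers; its nearest neighbour is compound 1, whose number is higher by a margin beyond the scatter, so compound 2 is the stronger of the two measured compounds at this concentration, though its effect remains modest.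

The unmeasured compound 3 `COc1cc2c(cc1O)CCC(C)(CCNC(C)=O)O2` is reached from compound 2 by one change: hydrogen in place of 3,4,5,6-tetrahydroxyoxan-2-yl on a saturated chain carbon bound to a carbonyl carbon. Without the tetrahydroxyoxanyl group, compound 3 carries a plain acetamide on the chain and comes close to compound 1, which showed no effect. Among the measured compounds shown here, no step between two measured compounds with this change is available, so the expectation rests on what compounds 1 and 2 show. Compound 3 is expected to move back toward compound 1, a small step upward in this assay, at the edge of the scatter: a number 8.8 percentage points higher from compound 2 to compound 3 (within the scatter). The estimate for compound 3 is 96%, with a range from 82% to 108%.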

Compound 3, a percentage reported as activity, at one concentration (the size of the read-out at that concentration, not a potency): 87.8%
For compound 3 the middle estimate is 8.2 percentage points above the measured one, within the range that was stated.
By their numbers in this assay, from the lowest: compounds 2 and 3 (each within the scatter of the next); then compound 1.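

In this assay, hydrogen in place of 3,4,5,6-tetrahydroxyoxan-2-yl on a saturated chain carbon bound to a carbonyl carbon gives a number 0.6 percentage points higher from compound 2 to compound 3 (within the scatter), so this large group, with its ring and four defined stereocentres, can leave this position without a change that this read-out can resolve. The second step, acetamidomethyl in place of carbamoyl on a saturated chain carbon bound to a saturated ring carbon, gives a number 12.2 percentage points lower from compound 1 to compound 3 (beyond the scatter), which places a modest difference on this change to the chain, with no tetrahydroxyoxanyl group present in compound 3. The data offer no measured reason for either step.

What the compounds shown leave open is whether the modest effect in this assay belongs to the acetamide itself or would also appear with another chain end, such as a primary amine or a carboxylic acid. They also leave open whether a longer chain between the shared core and the acetamide would change the reading, and how any of these compounds would behave at another concentration.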